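A few compounds are considered here, and "the series" means these few. Any claim that something is new, unique, unknown or untested is made for them only; others in the source may bear on it.

In a functional assay on HCT-116 cells (Homo sapiens) for cytotoxicity, read by MTT assay, with a stated time of 72 h (a higher number here means a weaker inhibitor, a lower number a stronger inhibitor), compound 1 `CS(=O)(=O)Oc1c(C(=O)NCc2ccc(F)cc2)nc(Br)c2cccnc12` gives > 20000 nM as a limit of the assay, not a number. Compound 2 `C[C@@H](Nc1c(C(=O)NCc2ccc(F)cc2)nc(Br)c2cccnc12)c1ccccc1` gives > 20000 nM as a limit too. Compound 3 `C[C@H](Nc1c(C(=O)NCc2ccc(F)cc2)nc(Br)c2cccnc12)c1ccccc1` gives > 20000 nM as a limit as well. The picture so far is therefore the limit of > 20000 nM in this assay, at which 3 of the 3 values shown sit, and no true strength is known for any of the three.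

Compound 4 `NCCCCCCNc1c(C(=O)NCc2ccc(F)cc2)nc(Br)c2cccnc12` carries 6-aminohexyl in place of 1-phenylethyl on a nitrogen on an aromatic ring and the group that enters has no ring. Among the measured compounds shown here, two measured steps touch this same spot: there is a step that the two limits leave unreadable from compound 1 to compound 3 and there is a step that the two limits leave unreadable from compound 2 to compound 3 and neither offers a size to carry over. Because compound 3 sits at > 20000 nM as a limit, any readable step can only run towards stronger inhibition. The expected change is an at least 2.5-fold lower number from compound 3 to compound 4 (0.39 log units; beyond the scatter) and this is a loose estimate. Compound 4 is estimated at 8000 nM with an expected range from 1500 nM to 30000 nM and another limit remains quite possible.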

Compound 4, half-maximal inhibitory concentration: 7000 nM
Compound 4: the middle estimate sits 1.1-fold (0.06 log units) above what was measured; the range from low to high includes it.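

In this assay, among the compounds shown here, this nitrogen on the shared core turns out to respond to the group it carries, which the earlier compounds could not show. Putting 6-aminohexyl in place of 1-phenylethyl gives a readable change whichever of the two mirror-image forms is the starting point (an at least 2.8-fold lower number from compound 3 to compound 4 (0.45 log units; beyond the scatter); an at least 2.8-fold lower number from compound 2 to compound 4 (0.45 log units; beyond the scatter)), and (6-aminohexyl)amino in place of (methylsulfonyl)oxy does too (an at least 2.8-fold lower number from compound 1 to compound 4 (0.45 log units; beyond the scatter)). For the compounds shown here, the steps among compounds 1, 2 and 3 cannot be read, and the three new steps give only the smallest possible size, with compound 4 the only one holding a true number: the limit of > 20000 nM in this assay, at which 3 of the 4 values shown sit.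

The change removes a ring and brings in a chain with an amine in one move, and these two parts remain unseparated. A plain hexyl group or a longer chain carrying the amine, on the same nitrogen, would tell them apart.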